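The source may hold more compounds than are shown below. What is called first, only, known or untested is meant among the compounds shown, and "the series" means these compounds.

Measured in a functional assay on A549 cells (Homo sapiens) for antiproliferative activity, with a stated time of 72 h; a lower number here means a stronger inhibitor, a higher number a weaker inhibitor:
- compound 1 `COc1ccccc1/C=C/c1nc(Nc2cccc(O)c2)c2ccccc2n1`: 16600 nM
- compound 2 `COc1ccc(/C=C/c2nc(Nc3cccc(O)c3)c3ccccc3n2)cc1`: 20800 nM

These two compounds share one core and differ only in the methoxyphenyl group on the chain. Compound 2, at 20800 nM, stands level with compound 1, since the step between them is a 1.3-fold higher number from compound 1 to compound 2 (0.10 log units; within the scatter). Neither compound can be ranked above the other in this assay.

The next compound, compound 3 `O=[N+]([O-])c1cccc(/C=C/c2nc(Nc3cccc(O)c3)c3ccccc3n2)c1`, has not yet been measured. It carries 3-nitrophenyl in place of 4-methoxyphenyl on a double-bonded chain carbon bound to a double-bonded chain carbon.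

For the measured compounds named here, only one measured step bears on this change, and it replaces one methoxyphenyl group with another at the same place. Going by the values given here, that step, a 1.3-fold higher number from compound 1 to compound 2 (0.10 log units; within the scatter), gives a modest guide at best, as no compound with a nitro group has been measured here. Among the compounds with values here, with no larger step to draw on, no change beyond the scatter is expected in this assay, and no direction can be firmly predicted. The expected step is a 1.2-fold lower number from compound 2 to compound 3 (0.06 log units; within the scatter). For compound 3 the estimated value is 18000 nM, with an expected range from 7000 nM to 45000 nM.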

Compound 3, half-maximal inhibitory concentration: 15400 nM
Estimate against measurement, compound 3: 1.2-fold (0.07 log units) above; low and high end bracket the measured number.
By their numbers in this assay, from the lowest: compounds 3, 1 and 2 (each within the scatter of the next).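

In this assay, 3-nitrophenyl on a double-bonded chain carbon bound to a double-bonded chain carbon does no differently from either methoxyphenyl group: replacing 4-methoxyphenyl gives a 1.4-fold lower number from compound 2 to compound 3 (0.13 log units; within the scatter) and replacing 2-methoxyphenyl gives a 1.1-fold lower number from compound 1 to compound 3 (0.03 log units; within the scatter) and both steps lie within the scatter. For the compounds shown here, the earlier pair showed only that two methoxyphenyl groups could not be told apart at this place, whereas this result extends that to a different substituent on the ring, one holding nitrogen and a double bond outside the aromatic ring. Nothing available explains why the three compounds cannot be separated in this assay.

The compounds shown leave open whether any group at this place can move the number beyond the scatter, and they do not separate the nature of the substituent from where it sits on the phenyl ring. As far as these compounds go, it also remains open how the number would respond to an amine or a carboxylic acid on that ring, or to a longer chain between the ring and the shared core.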